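The source may report more compounds than this note shows. Statements on the series, on what has been measured and on what is new or still open speak of the compounds shown alone.

In a functional assay on SK-BR-3 cells (Homo sapiens) for antiproliferative activity (a lower number here means a stronger inhibitor, a higher number a weaker inhibitor), two compounds sharing a core have been measured so far. Compound 1 `Cc1c(OC2CCN(C)CC2)ccc2cc(NC(=O)c3ccc(O)c(CCC(C)C)c3)c(=O)oc12` gives 600 nM and compound 2 `COc1cccc(-c2cc(C(=O)Nc3cc4ccc(OC5CCN(C)CC5)c(C)c4oc3=O)ccc2OC(C)=O)c1` gives 920 nM, so compound 2 stands within the scatter of compound 1. Compound 3 `COc1cccc(-c2cc(C(=O)Nc3cc4ccc(OC5CCN(C)CC5)c(C)c4oc3=O)ccc2O)c1` has not yet been measured. It differs from compound 2 by a single change, hydrogen in place of acetyl on an oxygen on an aromatic ring, which turns acetoxy to hydroxy: hydrogen in place of acetyl on an oxygen on an aromatic ring. Going by the values given here, no measured pair shows this change, so the data give no direct guide to its size. Among the compounds with values here, the only indication is that compound 1, which also carries a hydroxy on an aromatic ring, gives 600 nM. A step no larger than the scatter is therefore expected, with no firm direction. The expected step is a 1.3-fold lower number from compound 2 to compound 3 (0.12 log units; within the scatter). For compound 3 the estimate is 700 nM, with an expected range of 250 nM to 2000 nM.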

Compound 3, half-maximal inhibitory concentration: 860 nM
For compound 3 the middle estimate is 1.2-fold (0.09 log units) below the measured one; low and high end bracket the measured number.
By their numbers in this assay, from the lowest: compounds 1, 3 and 2 (each within the scatter of the next).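

With hydrogen in place of acetyl on an oxygen on an aromatic ring, this assay shows a 1.1-fold lower number from compound 2 to compound 3 (0.03 log units; within the scatter) and so does not separate acetoxy from hydroxy at this place. With the hydroxy held constant, 3-methoxyphenyl in place of isopentyl on an aromatic carbon gives a 1.4-fold higher number from compound 1 to compound 3 (0.16 log units; within the scatter) and so does not separate these two groups either, a comparison that compound 1 and compound 2 could not give, since they differ in two places. No measured evidence offers an explanation for these results.

Going by these compounds, whether a methyl or benzoyl group on this oxygen, or an amine in place of the whole hydroxy, would keep the number in this range remains open. On these data alone, it is equally open how a carboxylic acid or a longer chain would read on the aromatic carbon that carries 3-methoxyphenyl in compound 3.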